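A few compounds are considered here, and "the series" means these few. Any claim that something is new, unique, unknown or untested is made for them only; others in the source may bear on it.

Of the compounds shown here, three built on one shared core have been tested in an assay on HEK293 cells for inhibition of Steryl-sulfatase (Homo sapiens), tested at 0.1 uM; on this read-out lower numbers stand for a weaker effect and higher numbers for a stronger effect at the one concentration tested. Compound 1 `CN(C)CCCN(Cc1ccccc1)c1cccc(C(=O)N2CCc3ccc(OS(N)(=O)=O)cc3C2)c1` gives 23.8% in this assay, and compound 2 `CCCN(Cc1ccccc1)c1cccc(C(=O)N2CCc3ccc(OS(N)(=O)=O)cc3C2)c1` gives 23.1%. These two differ in a single place, (dimethylamino in place of hydrogen on a saturated chain carbon, three bonds along the chain from a nitrogen on an aromatic ring), and that change made a number 0.7 percentage points higher from compound 2 to compound 1 (within the scatter), so the two values show no separation worth naming.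

Compound 3 `CCCN(Cc1ccccc1)c1ccc(C(=O)N2CCc3ccc(OS(N)(=O)=O)cc3C2)cc1` is made of the same atoms as compound 2, joined differently; the difference between the two cores is not broken down here. In this assay compound 3 gives 64.8%, the highest of the three numbers, lying beyond the scatter from compound 1 and from compound 2 alike. Whatever sets compound 3 apart from compound 2, it is not a single counted change but a rearrangement of the same parts.

Compound 4 `CN(C)CCCN(Cc1ccccc1)c1ccc(C(=O)N2CCc3ccc(OS(N)(=O)=O)cc3C2)cc1` has not yet been measured. It relates to compound 3 exactly as compound 1 relates to compound 2: dimethylamino in place of hydrogen on a saturated chain carbon, three bonds along the chain from a nitrogen on an aromatic ring. This is the same change, at the same place, and it appears twice among the four compounds. A step of about the same size is expected from compound 3 to compound 4, namely a number 0.2 percentage points higher from compound 3 to compound 4 (within the scatter), because the same change from compound 2 to compound 1 made a number 0.7 percentage points higher from compound 2 to compound 1 (within the scatter). On that basis compound 4 is estimated at 65%, with a likely range from 50% to 78%.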

Compound 4, a percentage reported as inhibition, at one concentration (the size of the read-out at that concentration, not a potency): 16.2%
Beside the measured number, compound 4's estimate is 48.8 percentage points above it; measured number below the stated range.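

In this assay, the change of propyl to 3-(dimethylamino)propyl made a number 48.6 percentage points lower from compound 3 to compound 4 (beyond the scatter), so on these two cores the change did not carry over with the same size: the same change on two cores in this assay, a number 0.7 percentage points higher (within the scatter) from compound 2 to compound 1 and a number 48.6 percentage points lower (beyond the scatter) from compound 3 to compound 4, 49.3 percentage points apart, beyond the scatter of two such steps Within these four compounds, then, the step read on one core gave no usable guide to the step on the other, and the effect of adding dimethylamino at this place has to be read together with the core that carries it. What this does not show is why the two cores part, or whether the same split would hold on any further core, as it rests on just two pairs of compounds, each read at a single concentration.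

The compounds shown leave open whether the large step on the core of compound 3 belongs to dimethylamino itself or would also come with another group at the end of the propyl chain, such as a hydroxyl, a morpholine or a carboxylic acid. They also leave open how that step would change with a shorter or longer chain carrying the same amine, such as 2-(dimethylamino)ethyl.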